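Dimethylamino extension of the propylamide side chain

A few compounds are considered here, and "the series" means these few. Any claim that something is new, unique, unknown or untested is made for them only; others in the source may bear on it.

Measured so far:
compound 1, `CN(C)C(=O)Cn1c(-c2ccco2)nc2cccnc21` — > 100 mg/kg
compound 2, `CCCNC(=O)Cn1c(-c2ccc(Cl)cc2)nc2cccnc21` — 37.5 mg/kg

For the measured compounds named here, in a functional assay on the whole organism with Mus musculus as the target (on this read-out higher numbers stand for an effect only at larger amounts of compound and lower numbers for an effect already at smaller amounts), compound 2 gives 37.5 mg/kg, the only number in the set. For compound 1 the result is a limit of this assay, > 100 mg/kg, as noted in the limit of > 100 mg/kg in this assay, at which 1 of the 2 values shown sits. Compound 3, `CN(C)CCCNC(=O)Cn1c(-c2ccc(Cl)cc2)nc2cccnc21`, is not yet measured. It differs from compound 2 by dimethylamino in place of hydrogen on a saturated chain carbon, three bonds along the chain from an amide-type nitrogen. Going by the values given here, no measured pair isolates such a change, so the step of a 1.3-fold lower number from compound 2 to compound 3 (0.10 log units; within the scatter) is expected to be small, probably not beyond the usual scatter. Compound 3 is therefore estimated at 30 mg/kg, within 10 mg/kg to 100 mg/kg.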

Compound 3, dose for half-maximal effect: 64 mg/kg
Compound 3: middle estimate off by 2.1-fold (0.33 log units), on the low side; the range from low to high includes it.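

Propyl to 3-(dimethylamino)propyl gives the first single-place comparison in the series in this assay: a 1.7-fold higher number from compound 2 to compound 3 (0.23 log units; within the scatter). This chain end therefore carries dimethylamino with no step beyond the scatter, and compound 3 gives a number rather than a limit. Nothing on hand bears on the cause of this step.

Open, from the compounds shown here alone, is whether diethylamino, a carboxylic acid or a longer chain at this place would give a step beyond the scatter. Also open, going by these compounds, is whether dimethylamino behaves alike on the core of compound 1.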